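The compounds below may be only part of what the source reports. "The series", "measured", "known", "first", "only" and "open" are said of these compounds alone.

Compound 1 `Cc1nc(NC(=O)c2ccccc2)sc1C(=O)/C=C/c1ccccc1` is tested in an assay for inhibition of Polyunsaturated fatty acid 5-lipoxygenase (Homo sapiens), read by spectrophotometry, tested at 10 uM, in the presence of a further agent that is not named here (a lower number here means less inhibition, a higher number more inhibition at the concentration tested (going by the name of the read-out)), and compound 1 gives 73.5%. Compound 2 `Cc1nc(NC(=O)c2ccccc2)sc1C(=O)/C=C/c1ccc(F)cc1` differs from compound 1 by fluoro in place of hydrogen on an aromatic carbon and, in this assay, compound 2 gives 98%, a step of a number 24.5 percentage points higher from compound 1 to compound 2 (beyond the scatter). Compound 3 `Cc1ccc(/C=C/C(=O)c2sc(NC(=O)c3ccccc3)nc2C)cc1` differs from compound 1 by methyl in place of hydrogen on an aromatic carbon; in this assay compound 3 gives 75.1%. Compound 4 `Cc1ccc(/C=C/C(=O)c2sc(NC(=O)c3ccc(F)cc3)nc2C)cc1` is not yet measured; it differs from compound 3 by fluoro in place of hydrogen on an aromatic carbon, a change that on the wider view reads benzoyl to (4-fluorophenyl)carbonyl, so the fluorine enters a different ring than in compound 2. Because the earlier step was a number 24.5 percentage points higher from compound 1 to compound 2 (beyond the scatter), the step from compound 3 to compound 4 is expected to be a number 10.9 percentage points higher from compound 3 to compound 4 (beyond the scatter), though smaller since the ring is not the same one. Compound 4 is therefore estimated at 86%, between 70% and 98%.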

Compound 4, a percentage reported as inhibition, at one concentration (the size of the read-out at that concentration, not a potency): 91.5%
Compound 4: the middle estimate sits 5.5 percentage points below what was measured, within the range that was stated.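

In this assay, fluoro in place of hydrogen again gives a higher number, a number 16.4 percentage points higher from compound 3 to compound 4 (beyond the scatter). The two steps agree as far as the scatter can tell, so in these two pairs the change carries over, even though the fluorine enters a different ring in each: the same change on two cores in this assay, a number 24.5 percentage points higher (beyond the scatter) from compound 1 to compound 2 and a number 16.4 percentage points higher (beyond the scatter) from compound 3 to compound 4, 8.1 percentage points apart, within the scatter of two such steps. Among the compounds shown here, with only two pairs, read at a single concentration, this shows no general rule and says nothing about how potency itself shifts.

The compounds shown leave open whether fluoro on the benzoyl group of compound 1 gives a similar step, and whether fluoro on both rings would add up. They also leave open what a chlorine, a methoxy group or an amine in that place would do.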